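The compounds below may be only part of what the source reports. "The series", "measured", "known", "first", "only" and "open" are said of these compounds alone.

Measured so far:
Compound 1, `CC(C)n1ncc2c(C(=O)NCc3cn(-c4ccc([N+](=O)[O-])cc4)nn3)cccc21`, gives > 40000 nM in a functional assay on HepG2 cells (Homo sapiens) for inhibition, read by MTT assay, with a stated time of 72 h; a higher number here means a weaker inhibitor, a lower number a stronger inhibitor.
Compound 2, `Cc1ccccc1-n1cc(CNC(=O)c2cccc3c2cnn3C(C)C)nn1`, gives > 40000 nM in this assay.
Compound 3, `CC(C)n1ncc2c(C(=O)NCc3cn(-c4ccccc4F)nn3)cccc21`, gives > 40000 nM in this assay.

Each of these three values is a limit of this assay and not a number; compound 3 therefore stands only at a limit, and the two other values shown are limits as well, as the limit of > 40000 nM in this assay, at which 3 of the 3 values shown sit, records. The three steps among the measured compounds, a step that the two limits leave unreadable from compound 1 to compound 2, a step that the two limits leave unreadable from compound 1 to compound 3 and a step that the two limits leave unreadable from compound 2 to compound 3, are all left unreadable by the two limits, so none of them shows whether the group on the aromatic nitrogen changes the inhibition at all.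

Compound 4, `CC(C)n1ncc2c(C(=O)NCc3cn(-c4ccc(C(F)(F)F)cc4)nn3)cccc21`, has not been measured. It differs from compound 3 by 4-(trifluoromethyl)phenyl in place of 2-fluorophenyl on an aromatic nitrogen. Among the compounds with values here, the steps that bear on this change are the three unreadable ones above, and they give no size in either direction; what they do show is that three different groups on that aromatic nitrogen all leave the compound at the limit. Compound 4 is therefore expected to stay at the limit as well, a step that the limit leaves unreadable from compound 3 to compound 4 from compound 3. The estimate for compound 4 in this assay is 45000 nM, with a range from 20000 nM to 120000 nM, and most likely only a limit will be reported.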

Compound 4, half-maximal inhibitory concentration: > 40000 nM
Compound 4: a limit, no number; the forecaster's own chance of this, stated with the estimate: 80%; the middle value does not contradict the limit.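

In this assay compound 4 gives > 40000 nM, which is a limit and not a number. No new step can be read, as the steps to compound 4 from compound 1, compound 2 and compound 3 all join two limits. The compounds shown leave open whether any group on the aromatic nitrogen changes the inhibition, and how strongly any of these compounds inhibits.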